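The compounds below may be only part of what the source reports. "The series", "measured", "known", "first", "only" and "open" are said of these compounds alone.

For the measured compounds named here, compound 3, `CCOC(=O)c1cnc(-c2cccc(OC)c2)nc1NN1C(=O)C=C(C)C1=O`, sits second highest of the three numbers so far in a functional assay on Jurkat cells for inhibition of nuclear factor NF-kappa-B complex (Homo sapiens); on this read-out lower numbers stand for stronger inhibition and higher numbers for weaker inhibition: compound 3 gives 5000 nM. Compound 1, `CCOC(=O)c1cnc(C(F)(F)F)nc1NN1C(=O)C=C(C)C1=O`, gives 1000 nM in this assay, and compound 2, `CCOC(=O)c1cnc(C)nc1NN1C(=O)C=C(C)C1=O`, gives 16000 nM. The measured steps all concern one aromatic carbon of the shared core: a 16-fold higher number from compound 1 to compound 2 (1.20 log units; beyond the scatter), a 5.0-fold higher number from compound 1 to compound 3 (0.70 log units; beyond the scatter) and a 3.2-fold lower number from compound 2 to compound 3 (0.51 log units; beyond the scatter).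

Compound 4, `CCOC(=O)c1cnc(-c2cccc([N+](=O)[O-])c2)nc1NN1C(=O)C=C(C)C1=O`, changes a different place. Compared with compound 3, the difference is nitro in place of methoxy on an aromatic carbon; cut one bond further out it reads 3-methoxyphenyl to 3-nitrophenyl, sitting on an aromatic carbon of a six-membered aromatic ring of carbon only, meta to a large group. Going by the values given here, no measured step touches a substituent on that phenyl ring; the three steps above only swap the whole group on the core, so none of them bears directly on this change. With no guide of that kind, compound 4 is expected to stay close to compound 3, that is a step of no change at the digits printed from compound 3 to compound 4 (within the scatter), within the scatter. The estimate for compound 4 in this assay is 5000 nM, with a range from 1500 nM to 16000 nM.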

Compound 4, half-maximal inhibitory concentration: 7000 nM
For compound 4 the middle estimate is 1.4-fold (0.15 log units) below the measured one; low and high end bracket the measured number.
By their numbers in this assay, from the lowest: compound 1; then compounds 3 and 4 (each within the scatter of the next); then compound 2.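

In this assay, for the compounds shown here, nitro in place of methoxy gives a 1.4-fold higher number from compound 3 to compound 4 (0.15 log units; within the scatter) and so does not separate the two compounds, which is the first reading of a change on the phenyl ring rather than of a swap of the whole group on the core. The 3-nitrophenyl group also stands apart from the two small groups much as 3-methoxyphenyl does, with a 2.3-fold lower number from compound 2 to compound 4 (0.36 log units; beyond the scatter) against methyl and a 7.0-fold higher number from compound 1 to compound 4 (0.85 log units; beyond the scatter) against trifluoromethyl, so compound 3 and compound 4 both lie between compound 1 and compound 2. Nothing at hand offers a reason for this result.

The compounds shown carry only methoxy and nitro on that phenyl ring, at one place, so it stays open whether an amine or a carboxylic acid there would shift the number. In this assay, as far as these compounds go, compound 1 gives 1000 nM, and it is also open whether any group on that ring could bring a phenyl compound to the number of compound 1.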